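Fluoro for hydrogen on the phenoxy ring of compound 1

A few compounds are considered here, and "the series" means these few. Any claim that something is new, unique, unknown or untested is made for them only; others in the source may bear on it.

Compound 1 `NC1=NC2(CCOCC2)N(OCCCOc2ccccc2)C(N)=N1` is the parent of this small set. In an assay on isolated protein for inhibition of Dihydrofolate reductase (Homo sapiens), read by spectrophotometry, using NADPH, with stated times of 5 s and 6 min (a lower number here means a stronger inhibitor, a higher number a weaker inhibitor), compound 1 gives 86.1 nM, the highest of the two numbers recorded so far. Among the measured compounds shown here, compound 3 `NC1=NC2(CCOCC2)N(OCCCOc2ccc(Cl)cc2)C(N)=N1` carries chloro in place of hydrogen on an aromatic carbon; in this assay compound 3 gives 33.6 nM, and the step of a 2.6-fold lower number from compound 1 to compound 3 (0.41 log units; beyond the scatter) is the only measured step that bears on the present question. Compound 2 `NC1=NC2(CCSCC2)N(OCCCOc2cccc(Cl)c2)C(N)=N1`, with a different core and a chloro substituent, stands at "not determined" (no result reported) in this assay and contributes no number.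

Compound 4 `NC1=NC2(CCOCC2)N(OCCCOc2ccc(F)cc2)C(N)=N1` differs from compound 1 by fluoro in place of hydrogen on an aromatic carbon. This is the same kind of change as from compound 1 to compound 3, on the same aromatic carbon, with fluoro entering rather than chloro. That one relevant step lowered the number modestly and beyond the scatter, so a lowering in this assay is expected for compound 4 as well, though a smaller one that may remain within the scatter. The estimate for compound 4 is 60 nM, with a range of 30 nM to 120 nM, corresponding to the expected step of a 1.4-fold lower number from compound 1 to compound 4 (0.16 log units; within the scatter).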

Compound 4, half-maximal inhibitory concentration: 46.6 nM
Beside the measured number, compound 4's estimate is 1.3-fold (0.11 log units) above it; the measured number falls inside the stated range.
By their numbers in this assay, from the lowest: compounds 3, 4 and 1 (each within the scatter of the next, the first and the last beyond it).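

In this assay, fluoro on this aromatic carbon of the phenoxy ring gives a 1.8-fold lower number from compound 1 to compound 4 (0.27 log units; within the scatter), so this replacement alone does not separate from the parent, whereas chloro at the same place gives a 2.6-fold lower number from compound 1 to compound 3 (0.41 log units; beyond the scatter). The two halogens cannot be told apart at this carbon, with a 1.4-fold higher number from compound 3 to compound 4 (0.14 log units; within the scatter), so the data give no ranking of fluoro against chloro here. Nothing available on these compounds offers an account of these numbers.

The series shown gives numbers only for hydrogen, fluoro and chloro at this carbon, so the outcome with a methyl group, a methoxy group or an amine there remains open. Also open, from the compounds shown here alone, are whether a longer chain carrying the phenoxy ring would alter the fluoro step and whether that step would carry over to another core.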